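Cytotoxicity of anilinopyridines and anilinoquinolines bearing a tolyl group

The source may hold more compounds than are shown below. What is called first, only, known or untested is meant among the compounds shown, and "the series" means these compounds.

Measured compounds:
compound 1, `COc1ccc(Nc2ccc3ccccc3n2)cc1`, 51000 nM
compound 2, `COc1ccc(Nc2cc(-c3ccc(C)cc3)ccn2)cc1`, 43000 nM
compound 3, `COc1ccc(Nc2ccccn2)cc1`, 117000 nM

In a functional assay on HeLa cells (Homo sapiens) for cytotoxicity, read by MTT assay, with a stated time of 72 h (on this read-out lower numbers stand for stronger inhibition and higher numbers for weaker inhibition), compound 3 gives 117000 nM, and compound 2 gives 43000 nM. The change from compound 3 to compound 2 is 4-methylphenyl in place of hydrogen on an aromatic carbon, and it made the step of a 2.7-fold lower number from compound 3 to compound 2 (0.43 log units; beyond the scatter). Compound 1 gives 51000 nM in this assay; its value and that of compound 2 lie within the scatter of each other, while compound 3 stands beyond the scatter from both. The difference between the core of compound 1 and the core of compound 3 is not broken down here.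

Compound 4, `COc1ccc(Nc2nc3ccccc3cc2-c2ccc(C)cc2)cc1`, has not yet been measured. It differs from compound 1 by 4-methylphenyl in place of hydrogen on an aromatic carbon. This is the same kind of change as from compound 3 to compound 2, though it is placed ortho to a group of 9 heavy atoms, two atoms from the ring nitrogen, meta and para to a fused ring, rather than meta to that group and opposite the ring nitrogen. Resting on the step of a 2.7-fold lower number from compound 3 to compound 2 (0.43 log units; beyond the scatter), a step of a 2.0-fold lower number from compound 1 to compound 4 (0.31 log units; beyond the scatter) is expected from compound 1 to compound 4, somewhat smaller given the changed surroundings. Compound 4 is therefore estimated at 25000 nM, between 10000 nM and 60000 nM.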

Compound 4, half-maximal inhibitory concentration: 102000 nM
Estimate against measurement, compound 4: 4.1-fold (0.61 log units) below, outside the stated range (above it).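

In this assay, 4-methylphenyl in place of hydrogen on an aromatic carbon gave a 2.0-fold higher number from compound 1 to compound 4 (0.30 log units; within the scatter), so the lower number seen on the core of compound 3 did not carry over to the core of compound 1. Set side by side, the two steps do not agree, and this change cannot be carried unchanged from one core to the other in this series: the same change on two cores in this assay, a 2.7-fold lower number (0.43 log units; beyond the scatter) from compound 3 to compound 2 and a 2.0-fold higher number (0.30 log units; within the scatter) from compound 1 to compound 4, 5.4-fold (0.74 log units) apart, beyond the scatter of two such steps. What this does not show is the source of the disagreement: in compound 4 the group stands ortho to a group of 9 heavy atoms and two atoms from the ring nitrogen, and the core differs as well, so place and core cannot be told apart from these compounds.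

From the compounds shown here alone, it remains open how 4-methylphenyl would behave elsewhere on the core of compound 1, which would separate the two. Going by these compounds, it is also open whether an amine or a carboxylic acid in the same place would follow either step.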